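This account rests on a few compounds, and the source may have more. Where it says the series, first, only, none or still open, it means among the compounds named here.

Series notes on the aryl group carried by a saturated ring carbon of the shared core. Compound 1 `COc1cc(C2=NN(C(C)=O)C(c3c(Cl)cccc3Cl)O2)cc(OC)c1OC` gives -2.2% in a functional assay on PC-3 cells (Homo sapiens) for antiproliferative activity, read by MTT assay, tested at 5 uM; on this read-out lower numbers stand for a weaker effect and higher numbers for a stronger effect at the one concentration tested. Compound 2 `COc1ccc(OC)c(C2OC(c3cc(OC)c(OC)c(OC)c3)=NN2C(C)=O)c1` gives 43.2% in this assay, and compound 3 `COc1cc(C2=NN(C(C)=O)C(c3ccc(Cl)c(Cl)c3)O2)cc(OC)c1OC` gives 26.1% in this assay. Among these three numbers compound 3 stands second highest: the step of a number 17.1 percentage points lower from compound 2 to compound 3 (beyond the scatter) places it under compound 2, and the step of a number 28.3 percentage points higher from compound 1 to compound 3 (beyond the scatter) places it over compound 1. The largest step observed, a number 45.4 percentage points higher from compound 1 to compound 2 (beyond the scatter), belongs to an exchange at this same position.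

Compound 4 `COc1cc(C2=NN(C(C)=O)C(c3ccccc3F)O2)cc(OC)c1OC` remains to be measured in this assay. The change is 2-fluorophenyl in place of 3,4-dichlorophenyl on a saturated ring carbon. All three measured steps bear on it, since each swaps the group on this saturated ring carbon; two were modest and beyond the scatter, one large. Among the measured compounds shown here, the series holds no example of a fluorine-bearing ring at this position, so any expectation is loose. Given that compound 1 gives -2.2% with a chlorine-bearing ring of its own while compound 3 gives 26.1%, the step of a number 8.1 percentage points lower from compound 3 to compound 4 (within the scatter) is expected to be small to modest and downward, with wide uncertainty. Compound 4 is estimated at 18% in this assay, with a range from -5% to 40%.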

Compound 4, a percentage reported as inhibition, at one concentration (the size of the read-out at that concentration, not a potency): 31.6%
Compound 4: the middle estimate sits 13.6 percentage points below what was measured; low and high end bracket the measured number.
By their numbers in this assay, from the lowest: compound 1; then compounds 3 and 4 (each within the scatter of the next); then compound 2.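

In this assay the step of a number 5.5 percentage points higher from compound 3 to compound 4 (within the scatter) shows that a fluorine-bearing ring and a chlorine-bearing ring on this saturated ring carbon can give readings the assay does not separate, so 2-fluorophenyl and 3,4-dichlorophenyl sit together in the middle of the series. Among the compounds shown here, the other two steps, a number 11.6 percentage points lower from compound 2 to compound 4 (beyond the scatter) and a number 33.8 percentage points higher from compound 1 to compound 4 (beyond the scatter), keep compound 4 under the 2,5-dimethoxyphenyl compound and over the 2,6-dichlorophenyl compound, so a halogen on this ring does not by itself go with the low reading of compound 1, which remains the one compound of the four with almost no effect. No measurement at hand accounts for any of these differences.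

Still open, from the compounds shown here alone, is how a plain phenyl or a 2-chlorophenyl on this carbon would read against 2-fluorophenyl, which would help separate the effect of the halogen from that of the ring alone. Also open, going by these compounds, is whether an amine or a carboxylic acid on this aryl ring would keep the reading of compound 2 or lose it.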